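Nitro to benzyloxy: compound 2 to compound 3

A few compounds are considered here, and "the series" means these few. Any claim that something is new, unique, unknown or untested is made for them only; others in the source may bear on it.

Going by the values given here, in a functional assay on HT-1080 cells (Homo sapiens) for antiproliferative activity, read by MTT assay, with a stated time of 72 h (a lower number here means a stronger inhibitor, a higher number a weaker inhibitor), compound 2 `COc1ccc(-c2ccsc2-c2cc(OC)c(OC)c(OC)c2)cc1[N+](=O)[O-]` gives 8040 nM, the only exact number so far. Compound 1 `CCOC(=O)c1cc(-c2ccc(OC)c(OCc3ccccc3)c2)c(-c2cc(OC)c(OC)c(OC)c2)s1` gives > 100000 nM, which is a limit of the assay and not a number. Compound 3 `COc1ccc(-c2ccsc2-c2cc(OC)c(OC)c(OC)c2)cc1OCc1ccccc1` carries benzyloxy in place of nitro on an aromatic carbon, ortho to a methoxy group and meta to a large group: benzyloxy in place of nitro on an aromatic carbon. Among the compounds with values here, no measured single-place step is available to size this change. Weaker inhibition beyond the scatter in this assay is expected, an estimated 3.7-fold higher number from compound 2 to compound 3 (0.57 log units; beyond the scatter). This direction rests only on compound 1, which also carries benzyloxy and reads > 100000 nM. For compound 3 the estimated value is 30000 nM, with an expected range of 7000 nM to 100000 nM.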

Compound 3, half-maximal inhibitory concentration: > 100000 nM
Compound 3 was reported as a limit (the forecaster's own chance of this, stated with the estimate: 30%); middle value at least 3.3-fold (0.52 log units) away from the limit.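

In this assay, going by these compounds alone, benzyloxy in place of nitro on an aromatic carbon, ortho to a methoxy group, gives the first readable single-place step, an at least 12-fold higher number from compound 2 to compound 3 (1.09 log units; beyond the scatter). Compound 3 gives > 100000 nM, which is a limit of the assay and not a number, so the step has a lower bound but no upper one. The step from compound 1 to compound 3 cannot be read, so ethoxycarbonyl in place of hydrogen remains unsized, because of this limit: the limit of > 100000 nM in this assay, at which 2 of the 3 values shown sit.

Going by these compounds, what an amine or a hydroxyl group would read on this aromatic carbon remains open. Also open is whether the step follows from the arrival of benzyloxy or from the departure of nitro, since the compounds shown carry only these two groups here.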